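Changing the Halogen Pattern: What to Expect for Compound 3

This account rests on a few compounds, and the source may have more. Where it says the series, first, only, none or still open, it means among the compounds named here.

Compound 1 `O/N=C(\CCN1CCN(c2ccccn2)CC1)c1ccccc1Cl` gives 24 nM in a functional assay on HEK293 cells with D(4) dopamine receptor (Homo sapiens) as the target, read by FLIPR (on this read-out lower numbers stand for an effect already at smaller amounts and higher numbers for an effect only at larger amounts of compound), the lowest of the two numbers recorded. Compound 2 `O/N=C(\CCN1CCN(c2ccccn2)CC1)c1ccc(Cl)cc1` gives 475 nM in this assay, and the step of a 20-fold higher number from compound 1 to compound 2 (1.30 log units; beyond the scatter) shows that moving the single chlorine costs a great deal. Compound 3 `O/N=C(\CCN1CCN(c2ccccn2)CC1)c1ccc(F)cc1F` differs from compound 1 by 2,4-difluorophenyl in place of 2-chlorophenyl on a carbon with a double bond to nitrogen. Among the measured compounds shown here, only that one step bears on this change, and only loosely, since compound 3 shares features of both the 2-chlorophenyl and the 4-chlorophenyl patterns. A modest loss is expected, estimated as a 2.9-fold higher number from compound 1 to compound 3 (0.46 log units; beyond the scatter). Compound 3 is therefore estimated at 70 nM, within a range from 20 nM to 250 nM.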

Compound 3, half-maximal effective concentration: 8.9 nM
For compound 3 the middle estimate is 7.9-fold (0.90 log units) above the measured one; the whole stated range lies above it.
By their numbers in this assay, from the lowest: compound 3; then compound 1; then compound 2.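

In this assay, 2,4-difluorophenyl on this carbon improves on 2-chlorophenyl, with a 2.7-fold lower number from compound 1 to compound 3 (0.43 log units; beyond the scatter), and far more on 4-chlorophenyl, with a 53-fold lower number from compound 2 to compound 3 (1.73 log units; beyond the scatter). The large cost seen with 4-chlorophenyl therefore does not extend to every halogen-bearing phenyl group at this place. Nothing available explains why this group gives the lowest number of the three.

The compounds shown leave open whether the gain belongs to fluorine itself or to the presence of two halogens on the ring. Going by these compounds, how a plain phenyl group or a dichlorophenyl group would compare also remains unknown.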